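Turning Compound 1 Into Its Mirror Image

This account rests on a few compounds, and the source may have more. Where it says the series, first, only, none or still open, it means among the compounds named here.

Compound 1 `Cc1cc(C)c(CN2CCc3c(Cl)cc([C@H](CO)[C@@H]4CCCO4)c(Cl)c3C2=O)c(=O)[nH]1`: 57 nM
Compound 2 `CCOC(c1cc(Cl)c2c(c1Cl)C(=O)N(Cc1c(C)cc(C)[nH]c1=O)CC2)C1CS(=O)(=O)C1`: 5560 nM; 34 nM (2 entries)
Compound 3 `COC(C)c1cc(Cl)c2c(c1Cl)C(=O)N(Cc1c(C)cc(C)[nH]c1=O)CC2`: 696 nM; 282 nM (2 entries)

In a functional assay on KARPAS-422 cells (Homo sapiens) for antiproliferative activity, read by resazurin assay, with a stated time of 72 h (a lower number here means a stronger inhibitor, a higher number a weaker inhibitor), compound 1 gives a single number (57 nM), the only one here. Compound 2 and compound 3 each have two entries that disagree (the several entries of compound 2 in this assay, 5560 nM; 34 nM (2 entries) and (the several entries of compound 3 in this assay, 696 nM; 282 nM (2 entries))), so neither gives one clear value to compare with.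

The next compound is compound 4 `Cc1cc(C)c(CN2CCc3c(Cl)cc([C@@H](CO)[C@H]4CCCO4)c(Cl)c3C2=O)c(=O)[nH]1`, the mirror image of compound 1: the two compounds have the same atoms and bonds and differ only in configuration as drawn: 2 of 2 stereo elements differ (all stereocentres are inverted: mirror images); a stereocentre at a saturated chain carbon is drawn R in compound 1 and S in compound 4; a stereocentre at a saturated ring carbon is drawn S in compound 1 and R in compound 4 (all stereocentres are inverted). Its atoms and bonds stay the same, and only the configuration changes.

Among the measured compounds shown here, no measured pair here shows what such an inversion does, so any size is a judgement. Compound 1 (57 nM) lies close to the lower entry of compound 2 (the several entries of compound 2 in this assay, 5560 nM; 34 nM (2 entries)), so a loss seems likelier than a gain. The expected change a 6.1-fold higher number from compound 1 to compound 4 (0.79 log units; beyond the scatter) is therefore towards a weaker inhibitor, probably beyond the scatter, though this is uncertain. For compound 4 the estimated value is 350 nM (expected range 12 nM to 5000 nM).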

Compound 4, half-maximal inhibitory concentration: 535 nM
Beside the measured number, compound 4's estimate is 1.5-fold (0.18 log units) below it; the range from low to high includes it.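

In this assay, inverting both stereocentres gives a 9.4-fold higher number from compound 1 to compound 4 (0.97 log units; beyond the scatter), so the drawn configuration matters here, and compound 1 is the stronger of this pair. The change can be tied to configuration alone, because no atom or bond differs: the fact that compounds 1 and 4 differ only in the configuration as drawn. Compound 2 and compound 3 could not show this, as neither has a configuration drawn and each has two entries that disagree.

As far as these compounds go, both stereocentres change together in this pair, so it remains open whether the saturated chain carbon, the saturated ring carbon or both together account for the loss. From the compounds shown here alone, it is also open whether a carboxylic acid on the saturated chain carbon would leave a similar gap between two mirror images.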